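A few compounds are considered here, and "the series" means these few. Any claim that something is new, unique, unknown or untested is made for them only; others in the source may bear on it.

Measured so far in a functional assay on Caco-2 cells (Homo sapiens) for inhibition, read by sulforhodamine B assay, with a stated time of 48 h; a lower number here means a stronger inhibitor, a higher number a weaker inhibitor:

Compound 1, `CCO[C@H]1C[C@@H](c2coc3ccc(F)cc3c2=O)N(c2ccccc2)O1`, gives > 60000 nM; this is a limit of this assay rather than a number.
Compound 2, `CCO[C@H]1C[C@@H](c2coc3ccc(C)cc3c2=O)N(c2ccccc2)O1`, gives 31000 nM.
Compound 3, `COC(=O)[C@@]1(C)C[C@@H](c2coc3ccc(F)cc3c2=O)N(c2ccccc2)O1`, gives 29500 nM.

Compound 1 and compound 2 share one core and differ in a single place: methyl in place of fluoro on an aromatic carbon. In this assay that change gave an at least 1.9-fold lower number from compound 1 to compound 2 (0.28 log units; that floor lies within the scatter). Because the starting value sits at the limit of > 60000 nM in this assay, at which 1 of the 3 values shown sits, only a floor for the size of this step is known, and the floor itself lies within the usual scatter, so the change may have done little or a good deal more than the floor suggests.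

Compound 3 carries a different core; how its core differs from that of compound 1 is not broken down here. Its value and that of compound 2 lie within the scatter of each other, so no order between them can be read.

Compound 4, `COC(=O)[C@@]1(C)C[C@@H](c2coc3ccc(C)cc3c2=O)N(c2ccccc2)O1`, is not yet measured in this assay. It stands to compound 3 as compound 2 stands to compound 1, with the same change at the same kind of place: methyl in place of fluoro on an aromatic carbon. The step from compound 3 to compound 4 is expected to be a 2.0-fold lower number from compound 3 to compound 4 (0.29 log units; within the scatter), resting on the earlier step of the same change, an at least 1.9-fold lower number from compound 1 to compound 2 (0.28 log units; that floor lies within the scatter), with the caution that the earlier step is only a floor and compound 3 starts from a measured number rather than a limit. For compound 4 the expected value is 15000 nM, most likely lying between 5000 nM and 45000 nM.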

Compound 4, half-maximal inhibitory concentration: 19700 nM
Compound 4: middle estimate off by 1.3-fold (0.12 log units), on the low side; the range from low to high includes it.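

In this assay, placing methyl instead of fluoro on the other core gives a 1.5-fold lower number from compound 3 to compound 4 (0.18 log units; within the scatter), a step too small to separate from the differences seen between repeated measurements. Setting this beside the earlier step gives a first look at whether the change carries from one core to another, but the comparison cannot settle how closely the two steps agree: the same change on two cores in this assay, an at least 1.9-fold lower number (0.28 log units; that floor lies within the scatter) from compound 1 to compound 2 and a 1.5-fold lower number (0.18 log units; within the scatter) from compound 3 to compound 4; the limit leaves it open whether they differ. Neither step is shown to lie beyond the usual scatter, so the pair does not show that the change has a real effect of its own or that it carries over at a set size, and the earlier step has no known upper size, since it starts from a limit rather than a number: the limit of > 60000 nM in this assay, at which 1 of the 4 values shown sits.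

The compounds shown hold only methyl and fluoro at this place on the aromatic ring, so it remains open what a plain hydrogen, a chlorine, a methoxy, a nitrile or an amine there would give, and whether any of these would produce a step beyond the scatter. On these data alone, it also remains open whether methyl in place of fluoro would give a readable step on a third core, or on one with a lower starting value in this assay.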